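This account rests on a few compounds, and the source may have more. Where it says the series, first, only, none or still open, it means among the compounds named here.

Within the data shown here, compound 2, `O=C(/C=C1\CCc2ccc(F)cc21)N1CCC1`, stands lowest of the two compounds measured so far in a functional assay on the whole organism with Rattus norvegicus as the target, at a dose of 20 mg/kg by the oral route; on this read-out lower numbers stand for less inhibition and higher numbers for more inhibition at the one dose given (going by the name of the read-out): compound 2 gives 14%, while compound 1, `CNC(=O)/C=C1\CCc2ccc(F)cc21`, gives 45%. Among the measured compounds shown here, the single measured step, a number 31 percentage points lower from compound 1 to compound 2 (beyond the scatter), came with azetidin-1-yl in place of methylamino on a carbonyl carbon. Compound 3, `CCCNC(=O)/C=C1\CCc2ccc(F)cc21`, has not yet been measured; it differs from compound 2 by propylamino in place of azetidin-1-yl on a carbonyl carbon. This change undoes the earlier step in one respect: the four-membered ring leaves and one hydrogen-bond donor returns, although the group entering is propylamino rather than methylamino. Because the loss of the donor brought a number 31 percentage points lower from compound 1 to compound 2 (beyond the scatter), its return is expected to bring a rise of about a number 26 percentage points higher from compound 2 to compound 3 (beyond the scatter), with added uncertainty since the longer chain has no measured counterpart among these compounds. Compound 3 is therefore estimated to give 40%, within a range from 20% to 60%.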

Compound 3, a percentage reported as inhibition, in the whole organism at one dose (the size of the read-out at that dose, not a potency): 0%
Estimate against measurement, compound 3: 40 percentage points above; the whole stated range lies above it.
By their numbers in this assay, from the lowest: compound 3; then compound 2; then compound 1.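

In this assay, bringing back the amide hydrogen did not bring back the effect: propylamino in place of azetidin-1-yl on the carbonyl carbon gave a number 14 percentage points lower from compound 2 to compound 3 (beyond the scatter) and not a rise. Extending the methyl chain of compound 1 by ethyl gave a number 45 percentage points lower from compound 1 to compound 3 (beyond the scatter) and so placed the two compounds with an amide hydrogen at opposite ends of the order, which shows that the presence of this hydrogen alone does not set the number at this position. Nothing measured here explains why these groups differ so much.

Methylamino and propylamino alone cannot show whether the number falls steadily with chain length, and ethylamino would test the point between them. Going by these compounds, it also remains open whether dimethylamino or pyrrolidin-1-yl would give numbers close to those of azetidin-1-yl.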